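Trifluorophenyl in place of naphthyl on the piperazine nitrogen

The compounds below may be only part of what the source reports. "The series", "measured", "known", "first", "only" and "open" are said of these compounds alone.

Of the compounds shown here, three sharing one core have been measured in a functional assay on CHO cells with adenosine receptor A1 (Homo sapiens) as the target, read by cAMP accumulation and immunoassay, with a stated time of 6 min, tested at 0.01 uM; a lower number here means a stronger effect, a higher number a weaker effect of the compound at the concentration tested. Compound 1 `Nc1scc(CN2CCN(c3ccc([N+](=O)[O-])cc3)CC2)c1C(=O)c1ccc(Cl)cc1` gives -12%. Compound 2 `Nc1scc(CN2CCN(C3CCCCCC3)CC2)c1C(=O)c1ccc(Cl)cc1` gives 2.9%, and compound 3 `Nc1scc(CN2CCN(c3cccc4ccccc34)CC2)c1C(=O)c1ccc(Cl)cc1` gives 8.7%. Compound 3 thus stands beyond the scatter higher than compound 1, while its gap to compound 2 falls within the scatter, so those two cannot be ordered. The measured steps are a number 14.9 percentage points higher from compound 1 to compound 2 (beyond the scatter) and a number 20.7 percentage points higher from compound 1 to compound 3 (beyond the scatter), both modest, and a number 5.8 percentage points higher from compound 2 to compound 3 (within the scatter), which lies within the scatter.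

Compound 4 `Nc1scc(CN2CCN(c3c(F)cc(F)cc3F)CC2)c1C(=O)c1ccc(Cl)cc1` has not been measured. It differs from compound 3 by 2,4,6-trifluorophenyl in place of naphthalen-1-yl on an amine nitrogen in a ring. All three known steps concern swaps of the group on that same ring nitrogen, and the only ones beyond the scatter are those leaving the 4-nitrophenyl of compound 1. Moving between the cycloheptyl of compound 2 and the naphthalen-1-yl of compound 3 changed nothing beyond the scatter, so a further aryl swap is expected to do little. This amounts to an expected a number 6.7 percentage points lower from compound 3 to compound 4 (within the scatter). For compound 4 the expected value in this assay is 2%, with a range from -12% to 15%.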

Compound 4, a percentage reported as activity, at one concentration (the size of the read-out at that concentration, not a potency): 4.2%
The estimate for compound 4 lay 2.2 percentage points below the measured number; low and high end bracket the measured number.
By their numbers in this assay, from the lowest: compound 1; then compounds 2, 4 and 3 (each within the scatter of the next).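

In this test (this assay) the ring nitrogen of the piperazine-like ring accepts a third kind of group without a change that can be read. The swap from the two-ring naphthalen-1-yl to the one-ring 2,4,6-trifluorophenyl stays within the scatter (a number 4.5 percentage points lower from compound 3 to compound 4 (within the scatter)), and so does the swap from the non-aromatic cycloheptyl (a number 1.3 percentage points higher from compound 2 to compound 4 (within the scatter)), so compounds 2, 3 and 4 cannot be ordered. Compound 1 remains the only one set apart (a number 16.2 percentage points higher from compound 1 to compound 4 (beyond the scatter)), which shows that a single aromatic ring on this nitrogen does not by itself place a compound with compound 1, and no measurement at hand explains what does.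

Still open, going by these compounds, is whether the separation of compound 1 comes from its nitro group, and a plain phenyl, a 4-aminophenyl or a 4-methoxyphenyl on the same nitrogen would help to decide that. On these data alone, each number is also a read-out at a single concentration, so how these compounds compare in potency remains unknown.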